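Notes on an exocyclic substituent swap in a macrocyclic carbocycle series

The source may hold more compounds than are shown below. What is called first, only, known or untested is meant among the compounds shown, and "the series" means these compounds.

Measured compounds:
compound 1 `CC(=O)OC/C1=C/C[C@](C)(CCC=C(C)C)/C=C/[C@@H](OC(=O)C=C(C)C)[C@](C)(O)/C=C/C1=O`: 2950 nM
compound 2 `CC(=O)O[C@]1(C)/C=C/C(=O)/C(CO)=C\C[C@](C)(CCC=C(C)C)/C=C/[C@H]1OC(=O)C=C(C)C`: 3080 nM
compound 3 `CC(C)=CCC[C@]1(C)/C=C/[C@@H](OC(=O)C=C(C)C)[C@](C)(O)/C=C/C(=O)/C(CN(C)C)=C\C1`: 820 nM

In a functional assay on SMMC-7721 cells (Homo sapiens) for antiproliferative activity, read by MTT assay, with a stated time of 48 h (on this read-out lower numbers stand for stronger inhibition and higher numbers for weaker inhibition), compound 1 gives 2950 nM, the second highest of the three numbers. Compound 2 gives 3080 nM, within the scatter of compound 1. Compound 3 gives 820 nM, the lowest of the three. Compound 4 `CO/N=C/C1=C/C[C@](C)(CCC=C(C)C)/C=C/[C@@H](OC(=O)C=C(C)C)[C@](C)(O)/C=C/C1=O` differs from compound 1 by a group of 4 heavy atoms (2 carbon, 1 nitrogen, 1 oxygen; no ring) in place of a group of 5 heavy atoms (3 carbon, 2 oxygen; no ring), on a double-bonded ring carbon. Among the measured compounds shown here, the only step at this position is a 3.6-fold lower number from compound 1 to compound 3 (0.56 log units; beyond the scatter), where dimethylamino replaced acetoxy on the chain carbon; it was modest but beyond the scatter. For the measured compounds named here, the group entering compound 4 has no counterpart among the measured compounds, so that step bears on it only as a sign that changes here shift the number modestly. Expected for compound 4 is therefore a small step in this assay, toward a lower number or none beyond the scatter, a 1.5-fold lower number from compound 1 to compound 4 (0.17 log units; within the scatter). Compound 4 is estimated at 2000 nM, range 700 nM to 6000 nM.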

Compound 4, half-maximal inhibitory concentration: 3470 nM
Compound 4: the middle estimate sits 1.7-fold (0.24 log units) below what was measured; the range from low to high includes it.
By their numbers in this assay, from the lowest: compound 3; then compounds 1, 2 and 4 (each within the scatter of the next).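

In this assay the step of a 1.2-fold higher number from compound 1 to compound 4 (0.07 log units; within the scatter) lies within the scatter, so replacing acetoxymethyl at this double-bonded ring carbon does not by itself move the number. The step of a 4.2-fold higher number from compound 3 to compound 4 (0.63 log units; beyond the scatter) lies beyond the scatter, so among these replacements the lower number stays with the dimethylamino group of compound 3. Nothing available accounts for this difference. Still open, as far as these compounds go, is whether other amines, such as a primary amine or a morpholine, match dimethylamino here, and how a carboxylic acid or a longer chain at this place would read.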